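Changing the aryl group on the ring nitrogen

The source may report more compounds than this note shows. Statements on the series, on what has been measured and on what is new or still open speak of the compounds shown alone.

Compound 1 `CC(C)c1ccc(-n2nc(-c3ccc(C(F)(F)F)cc3O)nc2-c2ccccc2O)cc1`: 69.7%
Compound 2 `Oc1cc(C(F)(F)F)ccc1-c1nc(-c2ccccc2O)n(-c2ccc(F)cc2)n1`: 67.2%
Compound 3 `COc1ccccc1-n1nc(-c2ccc(C(F)(F)F)cc2O)nc1-c1ccccc1O`: 70.7%

In a functional assay on PC-12 cells (Rattus norvegicus) for cytotoxicity, read by MTT assay, with stated times of 2 h and 24 h, tested at 1 uM (a lower number here means a weaker effect, a higher number a stronger effect of the compound at the concentration tested), compound 3 gives 70.7%, the highest of the three numbers, yet its gaps to both neighbours, a number 1 percentage points higher from compound 1 to compound 3 (within the scatter) and a number 3.5 percentage points higher from compound 2 to compound 3 (within the scatter), stay within the scatter. Compound 4 `Oc1cc(C(F)(F)F)ccc1-c1nc(-c2ccccc2O)n(-c2cc(F)cc(F)c2)n1` differs from compound 3 in one place: 3,5-difluorophenyl in place of 2-methoxyphenyl on an aromatic nitrogen. The two measured changes of the group on this same aromatic nitrogen, a number 1 percentage points higher from compound 1 to compound 3 (within the scatter) and a number 3.5 percentage points higher from compound 2 to compound 3 (within the scatter), were both small, and the fluoro-for-isopropyl change a number 2.5 percentage points lower from compound 1 to compound 2 (within the scatter) was also within the scatter. A step of similar size is therefore expected here, a number 3.7 percentage points lower from compound 3 to compound 4 (within the scatter), with no direction beyond the scatter. Compound 4 is estimated at 67%, between 59% and 75%.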

Compound 4, a percentage reported as activity, at one concentration (the size of the read-out at that concentration, not a potency): 75.5%
The estimate for compound 4 lay 8.5 percentage points below the measured number; the measured number lies above the stated range.
By their numbers in this assay, from the lowest: compounds 2, 1, 3 and 4 (each within the scatter of the next).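

In this assay, the 3,5-difluorophenyl group on this aromatic nitrogen stays within the scatter of all three earlier aryl groups (a number 4.8 percentage points higher from compound 3 to compound 4 (within the scatter); a number 8.3 percentage points higher from compound 2 to compound 4 (within the scatter); a number 5.8 percentage points higher from compound 1 to compound 4 (within the scatter)). The four compounds therefore cannot be separated in this read-out, whether the aryl group carries two fluorines, one fluorine, an isopropyl or a methoxy group. Nothing here explains these small differences.

Still open, from the compounds shown here alone, is whether an amine or a carboxylic acid on this aryl ring would move the number beyond the scatter. The same question applies to a longer alkyl chain in place of the aryl group.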